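Swapping the adenine-like base for an oxo-bearing base

The source may hold more compounds than are shown below. What is called first, only, known or untested is meant among the compounds shown, and "the series" means these compounds.

Measured so far:
compound 1 `CC(C)C[C@H](O)C(=O)NS(=O)(=O)OC[C@H]1O[C@@H](n2cnc3c(N)ncnc32)[C@H](O)[C@@H]1O` — 2610 nM
compound 2 `CO[C@H](C(=O)NS(=O)(=O)OC[C@H]1O[C@@H](n2cnc3c(N)nc(Cl)nc32)[C@H](O)[C@@H]1O)[C@H](OC)C(C)C` — > 20000 nM

Both compounds were tested in a functional assay on MDA-MB-231 cells (Homo sapiens) for antiproliferative activity, read by sulforhodamine B assay, with a stated time of 72 h; a lower number here means a stronger inhibitor, a higher number a weaker inhibitor. Compound 1 gives the only numerical result in this assay, at 2610 nM. For compound 2 the assay reports a limit, > 20000 nM, not a number; one of the two values shown therefore sits at the limit of > 20000 nM in this assay, at which 1 of the 2 values shown sits.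

Compound 3 `CC(C)C[C@H](O)C(=O)NS(=O)(=O)OC[C@H]1O[C@@H](n2cnc3c(=O)[nH]cnc32)[C@H](O)[C@@H]1O` is not yet measured. It differs from compound 1 by a group of 10 heavy atoms (5 carbon, 4 nitrogen, 1 oxygen; one five-membered aromatic ring with 2 hetero atoms, one six-membered aromatic ring with 2 hetero atoms) in place of a group of 10 heavy atoms (5 carbon, 5 nitrogen; one five-membered aromatic ring with 2 hetero atoms, one six-membered aromatic ring with 2 hetero atoms), on a saturated ring carbon. Among the measured compounds shown here, the measured numbers give no step between two comparable compounds. The expected size of the change rests on the structural change alone. A shift towards weaker inhibition, larger than the usual scatter, is expected, with a step of a 4.6-fold higher number from compound 1 to compound 3 (0.66 log units; beyond the scatter). Compound 3 is therefore estimated at 12000 nM, within a range from 4000 nM to 30000 nM.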

Compound 3, half-maximal inhibitory concentration: > 20000 nM
Compound 3: no number, only a limit (the forecaster's own chance of this, stated with the estimate: 40%); middle value at least 1.6-fold (0.22 log units) from the limit.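

Among the compounds shown here, compound 3 keeps everything in compound 1 except the base on the saturated ring carbon next to the ring oxygen, so this is the first comparison here that isolates a single change. In this assay, replacing the adenine-like base with the oxo-bearing base gives an at least 7.6-fold higher number from compound 1 to compound 3 (0.88 log units; beyond the scatter), which shows that the activity of compound 1 does not survive this swap at this position. The result for compound 3 is a limit rather than a number, and values at this limit now make up most of the set: the limit of > 20000 nM in this assay, at which 2 of the 3 values shown sit.

Going by these compounds, the true size of the loss stays open, as the step gives only its lower bound. Also open, on these data alone, is whether a methylamino or methoxy group on the base, in place of the oxo group, would retain activity.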